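Methylating a Catechol Hydroxyl on Compound 2

The source may report more compounds than this note shows. Statements on the series, on what has been measured and on what is new or still open speak of the compounds shown alone.

In a functional assay, with a stated time of 30 min (on this read-out lower numbers stand for stronger inhibition and higher numbers for weaker inhibition), compound 1 `COC1(CC(C)=O)Oc2cc(/C=C/c3ccc(O)c(O)c3)oc(=O)c2/C1=C/c1ccc(O)c(O)c1` gives 40000 nM. Compound 2 `COC1(C)Oc2cc(/C=C/c3ccc(O)c(O)c3)oc(=O)c2/C1=C/c1ccc(O)c(O)c1` gives 95000 nM in this assay, the higher of the two numbers, reached through a 2.4-fold higher number from compound 1 to compound 2 (0.38 log units; beyond the scatter). Compound 3 `COc1cc(/C=C/c2cc3c(c(=O)o2)/C(=C/c2ccc(O)c(O)c2)C(C)(OC)O3)ccc1O` differs from compound 2 by methyl in place of hydrogen on an oxygen on an aromatic ring. Going by the values given here, no measured step touches this change; the single measured step concerns another place in the shared core and offers no guide. Compound 3 is therefore expected to show a step of a 1.6-fold higher number from compound 2 to compound 3 (0.20 log units; within the scatter) in this assay. Compound 3 is estimated at 150000 nM, within a range of 50000 nM to 450000 nM.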

Compound 3, half-maximal inhibitory concentration: 38000 nM
Beside the measured number, compound 3's estimate is 3.9-fold (0.60 log units) above it; the whole stated range lies above it.
By their numbers in this assay, from the lowest: compounds 3 and 1 (each within the scatter of the next); then compound 2.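

Swapping hydrogen for methyl on an oxygen on an aromatic ring, hydroxy to methoxy, gives a 2.5-fold lower number from compound 2 to compound 3 (0.40 log units; beyond the scatter) in this assay. This shows that the 3,4-dihydroxyphenyl group of compound 2 can become 4-hydroxy-3-methoxyphenyl without any loss on this read-out, and that this place, untouched by the earlier step, does affect the number. No evidence is at hand that accounts for this step.

From the compounds shown here alone, whether ethyl or a longer chain on this oxygen would behave like methyl remains open. So does the effect of methoxy on the other 3,4-dihydroxyphenyl group that compound 3 retains.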